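This account rests on a few compounds, and the source may have more. Where it says the series, first, only, none or still open, it means among the compounds named here.

Among the compounds with values here, compound 2 `C=C1CC[C@@H]2[C@](C)(CO[Si](C)(C)C(C)(C)C)[C@H](OC(C)=O)CC[C@@]2(C)[C@@H]1C/C=C1/C(=O)OC[C@H]1OC(C)=O` gives the lower of the two numbers measured so far in a functional assay on P388 cells (Mus musculus) for cytotoxicity, read by sulforhodamine B assay (on this read-out higher numbers stand for an effect only at larger amounts of compound and lower numbers for an effect already at smaller amounts), namely 0.34 uM. Within the data shown here, its only neighbour, compound 1 `C=C1CC[C@@H]2[C@](C)(CO)[C@H](OC(C)=O)CC[C@@]2(C)[C@@H]1C/C=C1/C(=O)OC[C@H]1OC(C)=O`, gives 0.69 uM in this assay. That modest step, a 2.0-fold lower number from compound 1 to compound 2 (0.31 log units; beyond the scatter), came from putting a bulky silicon-containing group in place of a hydrogen atom on an oxygen on a saturated carbon. Compound 3 `C=C1CC[C@@H]2[C@](C)(CO[Si](C)(C)C(C)(C)C)[C@H](O)CC[C@@]2(C)[C@@H]1C/C=C1/C(=O)OC[C@H]1OC(C)=O` has not yet been measured. It differs from compound 2 by hydrogen in place of acetyl on an oxygen on a saturated carbon, which amounts to acetoxy becoming hydroxy on an oxygen on a saturated carbon whose other neighbour is a saturated ring carbon. Among the measured compounds shown here, no measured step touches this position or this kind of exchange, so the only guide is the narrow spread of the two known numbers. The step of a 1.5-fold higher number from compound 2 to compound 3 (0.17 log units; within the scatter) is therefore expected to stay within the scatter. For compound 3 the estimated value in this assay is 0.5 uM, within a range from 0.2 uM to 1.5 uM.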

Compound 3, concentration for half-maximal effect: 1.03 uM
Compound 3: middle estimate off by 2.1-fold (0.31 log units), on the low side, and the stated range covers the measured number.
By their numbers in this assay, from the lowest: compound 2; then compounds 1 and 3 (each within the scatter of the next).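

The acetoxy group on this oxygen is not a neutral passenger in this assay: exchanging it for hydroxy gives a 3.0-fold higher number from compound 2 to compound 3 (0.48 log units; beyond the scatter), so the number responds to a change at this position. Within the data shown here, the earlier pair of compounds changed only the other oxygen, the one carrying the silicon-containing group, and so said nothing about this site. Nothing measured here gives a reason for this step.

The compounds shown leave open whether the acetyl itself matters, since a methyl ether or a longer ester such as a benzoate on this oxygen could show whether other groups keep the number near that of compound 2. Going by these compounds, it also remains open whether acetoxy becoming hydroxy gives a similar step when the other oxygen carries hydrogen, as in compound 1.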